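Chloro added to the phenyl of compound 2

This account rests on a few compounds, and the source may have more. Where it says the series, first, only, none or still open, it means among the compounds named here.

Values in a functional assay on CCRF-CEM cells (Homo sapiens) for antiproliferative activity, read by MTT assay, with a stated time of 24 h, tested at 25 uM; a lower number here means a stronger effect, a higher number a weaker effect of the compound at the concentration tested:
compound 1, `OCC(O)Cn1nc2c(Br)c(Br)c(Br)c(Br)c2n1`: 89%
compound 2, `OC(CCn1nc2c(Br)c(Br)c(Br)c(Br)c2n1)c1ccccc1`: 123%

Among the compounds with values here, of the two measured compounds, compound 2 gives the highest number; its only neighbour, compound 1, lies lower by a gap beyond the usual scatter. No pair of measured compounds differs in a single place, so no step size is known within the set, and no cause for the gap between compound 1 and compound 2 can be read from the data.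

Compound 3 `OC(CCn1nc2c(Br)c(Br)c(Br)c(Br)c2n1)c1ccc(Cl)cc1` is the next compound to go into this assay. Relative to compound 2 the change is chloro in place of hydrogen on an aromatic carbon. Within the data shown here, nothing measured so far bears on what this change does in this assay. The expectation for the step from compound 2 to compound 3 is a small one, if any, with no direction preferred beyond the scatter; the size expected is a number 11 percentage points lower from compound 2 to compound 3 (beyond the scatter). For compound 3 the estimated value in this assay is 112%, with a range from 85% to 135%.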

Compound 3, a percentage reported as activity, at one concentration (the size of the read-out at that concentration, not a potency): 106%
Beside the measured number, compound 3's estimate is 6 percentage points above it; measured number inside the range.
By their numbers in this assay, from the lowest: compound 1; then compound 3; then compound 2.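

In this assay, within the data shown here, phenyl to 4-chlorophenyl gives a number 17 percentage points lower from compound 2 to compound 3 (beyond the scatter), the first single-place step, so a change at this position can move the read-out by more than the usual scatter. The direction is towards a stronger effect at the tested concentration, and a single chloro on an aromatic carbon, para to a large group, is enough to produce it; this is a shift in a read-out at one concentration and says nothing about potency. The data offer no measured property or other finding that accounts for this step.

On these data alone, what stays open is whether the step belongs to chloro itself or would appear with any other group at this position, such as fluoro, methoxy, an amine or a carboxylic acid. Also open, as far as these compounds go, is whether the same step would hold with a longer chain between the shared core and the carbon that bears the hydroxyl group, since a single pair cannot show how far it carries.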